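The source may hold more compounds than are shown below. What is called first, only, known or untested is meant among the compounds shown, and "the series" means these compounds.

Measured compounds:
compound 1, `CC[C@H](C)[C@H](NC(=O)c1cccc(Cn2ccnc2)c1)C(=O)Nc1nccs1`: in an assay on HEK293 cells for displacement of a labelled ligand from Type-2 angiotensin II receptor (Homo sapiens), tested at 1 uM (on this read-out higher numbers stand for a stronger effect at the one concentration tested and lower numbers for a weaker effect), compound 1 gives 4%
compound 2, `CCCCNC(=O)[C@@H](NC(=O)c1cccc(Cn2ccnc2)c1)[C@@H](C)CC`: in this assay compound 2 is reported as "not active" (no number reported)

Compound 1 holds the only numerical result shown in this assay, and that result is a small one; compound 2 adds no number, only the report that it is not active in this assay. Among the compounds with values here, no pair of measured compounds differs in a single place, so no measured step is available to guide an expectation.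

Compound 3, `CC[C@H](C)[C@H](NC(=O)c1cccc(Cn2ccnc2)c1)c1nn[nH]n1`, has not yet been measured. It is derived from compound 1 by one change: 2H-tetrazol-5-yl in place of (1,3-thiazol-2-yl)carbamoyl on a saturated chain carbon bound to an amide-type nitrogen and a saturated chain carbon. From the compounds shown here alone, what this exchange does in this assay is unknown from the data at hand.

Given that the only number shown, for compound 1, is low, the change is expected to produce no shift beyond the usual scatter, the step being estimated as a number 1 percentage points higher from compound 1 to compound 3 (within the scatter). For compound 3 the inhibition in this assay is therefore estimated at 5%, with a range from -10% to 25%.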

Compound 3, a percentage reported as inhibition, at one concentration (the size of the read-out at that concentration, not a potency): "not active" (no number reported)
For compound 3 the study gives words and no number; there is nothing to compare the estimate with.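

Compound 3 is reported only as not active in this assay, so no step can be read from compound 1 at 4% to compound 3. The compounds shown leave open whether any exchange on that saturated chain carbon moves the inhibition beyond the usual scatter. No measurement shown offers an explanation for this result.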